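From Bromo to Fluoro on the Aromatic Carbon

The source may report more compounds than this note shows. Statements on the series, on what has been measured and on what is new or still open speak of the compounds shown alone.

In a toxicity assay on the whole organism with Rattus norvegicus as the target, at a dose of 200 mg/kg by the oral route (a higher number here means a stronger effect of the compound at the dose given, a lower number a weaker effect), compound 3 `Brc1ccc(OCC2=NCCO2)cc1` gives 10%, level with compound 1 `COc1ccc(OCC2=NCCO2)cc1` at 10%, the two together being the lowest of the three numbers seen; compound 2 `Clc1ccc(OCC2=NCCO2)cc1` gives 20%, and the step of a number 10 percentage points lower from compound 2 to compound 3 (within the scatter) stays within the scatter, as does no change at the digits printed from compound 1 to compound 3 (within the scatter).

Compound 4 `Fc1ccc(OCC2=NCCO2)cc1` differs from compound 3 by fluoro in place of bromo on an aromatic carbon. Among the measured compounds shown here, the steps that bear on this exchange are the earlier substituent swaps at the same aromatic carbon, a number 10 percentage points higher from compound 1 to compound 2 (within the scatter) and a number 10 percentage points lower from compound 2 to compound 3 (within the scatter), both within the scatter. A step of no change at the digits printed from compound 3 to compound 4 (within the scatter) is therefore expected in this assay, none beyond the scatter. Compound 4 is estimated at 10%, within a range from 0% to 25%.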

Compound 4, a percentage reported as activity, at one dose (the size of the read-out at that dose, not a potency): 25%
The estimate for compound 4 lay 15 percentage points below the measured number; low and high end bracket the measured number.
By their numbers in this assay, from the lowest: compounds 1, 3, 2 and 4 (each within the scatter of the next, the first and the last beyond it).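

In this assay, among the compounds shown here, the exchange for fluoro gives the first steps at this aromatic carbon that pass the scatter, a number 15 percentage points higher from compound 3 to compound 4 (beyond the scatter) and a number 15 percentage points higher from compound 1 to compound 4 (beyond the scatter) while a number 5 percentage points higher from compound 2 to compound 4 (within the scatter) leaves fluoro and chloro unseparated. The order among the substituents thus rests on the bromo and methoxy compounds alone, not on halogens as a class, with chloro going against any clean split between them. Nothing measured bears on why this step occurs. On these data alone, how an amine or a carboxylic acid at this carbon would read remains open, as does a longer chain there.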